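Amine swap on the propoxy chain: expectation for compound 4

This account rests on a few compounds, and the source may have more. Where it says the series, first, only, none or still open, it means among the compounds named here.

Compound 1 `CCN(CC)CCCOc1cc2ncnc(Nc3nc4ccc(C(=O)Nc5c(C)cccc5C)cc4s3)c2cc1OC` gives 28400 nM in a functional assay on K562 cells (Homo sapiens) for cytotoxicity, read by WST assay, with a stated time of 72 h; a higher number here means a weaker inhibitor, a lower number a stronger inhibitor. Compound 2 `CCN(CC)CCCOc1cc2ncnc(Nc3nc4ccc(C(=O)Nc5c(C)cccc5Cl)cc4s3)c2cc1OC` gives 9600 nM in this assay, and compound 3 `COc1cc2c(Nc3nc4ccc(C(=O)Nc5c(C)cccc5C)cc4s3)ncnc2cc1OCCCN1CCC(C)CC1` gives 15800 nM in this assay. Two single changes link these: a 3.0-fold lower number from compound 1 to compound 2 (0.47 log units; beyond the scatter), a modest but clear gain; and a 1.8-fold lower number from compound 1 to compound 3 (0.25 log units; within the scatter), which does not leave the scatter. Compound 2 therefore sits at the low end of the three numbers, yet compound 3 lies within the scatter of it, so the two cannot be ranked; only compound 1 stands clearly apart from compound 2.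

Compound 4 `COc1cc2c(Nc3nc4ccc(C(=O)Nc5c(C)cccc5Cl)cc4s3)ncnc2cc1OCCCN1CCCCC1` is not yet measured. Its change from compound 2 is piperidin-1-yl in place of diethylamino on a saturated chain carbon, three bonds along the chain from an oxygen on an aromatic ring. For the measured compounds named here, the one measured step that bears on this is the step from compound 1 to compound 3, where the same place on the chain received 4-methylpiperidin-1-yl in place of diethylamino and the number moved only within the scatter. Swapping diethylamino for piperidin-1-yl is expected to behave alike, with no step beyond the scatter in this assay and, if anything, a slightly lower number.

Compound 4 is expected at 8000 nM, with a range from 4000 nM to 16000 nM. The expected step is a 1.2-fold lower number from compound 2 to compound 4 (0.08 log units; within the scatter), inside the usual scatter.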

Compound 4, half-maximal inhibitory concentration: 12500 nM
Estimate against measurement, compound 4: 1.6-fold (0.19 log units) below, and the stated range covers the measured number.
By their numbers in this assay, from the lowest: compounds 2, 4, 3 and 1 (each within the scatter of the next, the first and the last beyond it).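

In this assay, the swap at this place gives a 1.3-fold higher number from compound 2 to compound 4 (0.11 log units; within the scatter), so the saturated chain carbon, three bonds along the chain from an oxygen on an aromatic ring, now has a second amine change that stays within the scatter, and this time an unsubstituted piperidin-1-yl ring replaces diethylamino. The earlier swap, a 1.8-fold lower number from compound 1 to compound 3 (0.25 log units; within the scatter), was read with methyl on the aromatic carbon and this one with chloro there, so the tolerance for exchanging diethylamino for a six-membered ring amine holds in both listed pairs, and neither step gives a direction that can be read. No measurement shown here accounts for the result.

From the compounds shown here alone, whether a different terminal group on the 3-aminopropyl chain, such as morpholin-4-yl, 4-methylpiperazin-1-yl or a carboxylic acid, or a longer chain, would carry the number beyond the scatter remains open. Going by these compounds, the step of a 3.0-fold lower number from compound 1 to compound 2 (0.47 log units; beyond the scatter) is also read only with diethylamino on the chain, so its size with piperidin-1-yl or 4-methylpiperidin-1-yl in that place remains open too.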